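The source may report more compounds than this note shows. Statements on the series, on what has been measured and on what is new or still open speak of the compounds shown alone.

Compound 1: `O=C1CCCCN1c1ccc(C#Cc2c(F)cccc2F)cc1`, giving 68.1%.
Compound 2: `CN(C)c1ccc(C#Cc2c(F)cccc2F)cn1`, giving 83.6%.

Both numbers come from a functional assay on LS174T cells (Homo sapiens) for inhibition, with a stated time of 4 days, tested at 10 uM; a higher number here means a stronger effect of the compound at the concentration tested, a lower number a weaker effect. Compound 2 stands at the higher of the two numbers, and its nearest neighbour, compound 1, sits lower by an amount that goes beyond the usual scatter of the measurement, so the two can be told apart. Compound 3, `Fc1cccc(F)c1C#Cc1ccc(-n2cccc2)nc1`, has not yet been tested. It differs from compound 2 in a single place: 1H-pyrrol-1-yl in place of dimethylamino on an aromatic carbon. Among the measured compounds no pair differs in exactly this way, so there is no measured step that shows what this change does on its own; the two measured compounds differ from each other in more than one place, and their values say nothing about the 1H-pyrrol-1-yl group. The expectation for compound 3 therefore rests on compound 2 and its 83.6%, with a wide range. The expected step is a number 9.6 percentage points lower from compound 2 to compound 3 (within the scatter), modest in size and more likely downward than upward, though it may stay within the scatter. For compound 3 an inhibition of 74% is estimated, expected to fall between 50% and 92%.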

Compound 3, a percentage reported as inhibition, at one concentration (the size of the read-out at that concentration, not a potency): 95.3%
Beside the measured number, compound 3's estimate is 21.3 percentage points below it; measured number above the stated range.
By their numbers in this assay, from the lowest: compound 1; then compound 2; then compound 3.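

In this assay, putting 1H-pyrrol-1-yl in place of dimethylamino on the aromatic carbon next to the ring nitrogen gives a number 11.7 percentage points higher from compound 2 to compound 3 (beyond the scatter), the first measured effect of a change in one place in this set. This position therefore accepts a five-membered aromatic ring where compound 2 carries a group with no ring, and the inhibition at the tested concentration does not suffer but rises. The compounds shown offer no measurement that explains this rise.

As far as these compounds go, it remains open which feature of the new group matters, the ring itself or its aromatic character: pyrrolidin-1-yl, a saturated five-membered ring on the same carbon, would help to separate the two, and imidazol-1-yl would show what a second ring nitrogen does. From the compounds shown here alone, it is also open how far the difference holds at other concentrations: a read-out at one concentration gives the size of the effect at that concentration, and compound 3 already stands close to the top of the percentage scale.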